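The source may hold more compounds than are shown below. What is called first, only, known or untested is meant among the compounds shown, and "the series" means these compounds.

Measured compounds:
Compound 1, `Oc1cccc(-c2cc(-c3cccnc3)cc(-c3ccccc3O)n2)c1`: 5580 nM
Compound 2, `Oc1cccc(-c2cc(-c3cccnc3)cc(-c3cccc(O)c3)n2)c1`: the assay limit, > 50000 nM

Both compounds share a core bearing a pyridin-3-yl group and a 3-hydroxyphenyl group, and differ only in the third aromatic group. In a functional assay on DU-145 cells (Homo sapiens) for cytotoxicity, read by CCK-8 assay (a higher number here means a weaker inhibitor, a lower number a stronger inhibitor), compound 1 gives 5580 nM. For compound 2 this assay reports only a limit, > 50000 nM, so its true potency is not pinned down (the limit of > 50000 nM in this assay, at which 1 of the 2 values shown sits). Among the compounds with values here, the single measured step, an at least 8.9-fold higher number from compound 1 to compound 2 (0.95 log units; beyond the scatter), shows that exchanging 2-hydroxyphenyl for 3-hydroxyphenyl on the shared core weakens inhibition at least modestly.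

Compound 3, `Oc1ccc(-c2cc(-c3cccnc3)cc(-c3cccc(O)c3)n2)cc1`, carries the change (4-hydroxyphenyl in place of 3-hydroxyphenyl on an aromatic carbon). No measured step tests this particular exchange; the one step shown bears on it only indirectly, by indicating that this position is sensitive to where the hydroxyl sits. Compound 3 is therefore expected to stay at the weak end, with an estimated step of a number no higher from compound 2 to compound 3 (the limit leaves the size open). The estimate for compound 3 is 50000 nM, within 10000 nM to 200000 nM.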

Compound 3, half-maximal inhibitory concentration: 6390 nM
The estimate for compound 3 lay 7.8-fold (0.89 log units) above the measured number, and the stated range ends above it.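

The change gives an at least 7.8-fold lower number from compound 2 to compound 3 (0.89 log units; beyond the scatter), so moving the hydroxyl further around this phenyl group does not weaken inhibition step by step: the loss seen with 3-hydroxyphenyl does not carry over to 4-hydroxyphenyl. The other new step, a 1.1-fold higher number from compound 1 to compound 3 (0.06 log units; within the scatter), means that 2-hydroxyphenyl and 4-hydroxyphenyl cannot be told apart here, and among these three compounds only the 3-hydroxyphenyl group of compound 2 stands out. The size of that gap remains a minimum, since compound 2 gives a limit and not a number: the limit of > 50000 nM in this assay, at which 1 of the 3 values shown sits.

On these data alone, whether the hydroxyl itself matters remains open, as does the effect of a plain phenyl group, or of a methoxy group or an amine in the hydroxyl's place. As far as these compounds go, it is also open whether the same pattern would hold on a core without the second 3-hydroxyphenyl group.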